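The source may hold more compounds than are shown below. What is called first, only, known or untested is meant among the compounds shown, and "the series" means these compounds.

Measured so far in an ADME assay on a cell-free system (plasma, Homo sapiens) for metabolic stability, with Plasma (Rattus norvegicus) as the target, read by HPLC, at pH 7.4; a lower number here means that the compound disappears faster, a higher number that the compound lasts longer:
compound 1 `CC(=O)Oc1ccccc1C(=O)O[C@H]1CO[C@H]2[C@@H]1OC[C@H]2OC(=O)c1ccc(O)cc1` gives 0.0198 h;
compound 2 `CC(=O)Oc1ccccc1C(=O)O[C@H]1CO[C@H]2[C@@H]1OC[C@H]2OC(C)=O` gives 0.0608 h;
compound 3 `CCC(=O)O[C@@H]1CO[C@H]2[C@@H]1OC[C@@H]2OC(=O)c1ccccc1OC(C)=O` gives 0.0608 h.

Compound 1 stands lowest of the three, with a 3.1-fold higher number from compound 1 to compound 2 (0.49 log units; beyond the scatter) and a 3.1-fold higher number from compound 1 to compound 3 (0.49 log units; beyond the scatter), while compounds 2 and 3 show no change at the digits printed from compound 2 to compound 3 (within the scatter). Compound 4 `CC(=O)Oc1ccccc1C(=O)O[C@H]1CO[C@H]2[C@@H]1OC[C@H]2OC(=O)c1ccc([N+](=O)[O-])cc1` differs from compound 1 as follows: nitro in place of hydroxy on an aromatic carbon. Among the compounds with values here, no measured step exchanges one group on the aromatic ring for another; the two known steps from compound 1 remove the whole 4-hydroxyphenyl group and put a small alkyl in its place, so they do not bear directly on this change. With nothing closer to go on, the expected step in this assay is a 1.1-fold higher number from compound 1 to compound 4 (0.05 log units; within the scatter), none beyond the scatter. Compound 4 is therefore estimated at 0.022 h, with a range from 0.01 h to 0.055 h.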

Compound 4, half-life: 0.0462 h
Compound 4: middle estimate off by 2.1-fold (0.32 log units), on the low side; measured number inside the range.
By their numbers in this assay, from the lowest: compound 1; then compounds 4, 2 and 3 (each within the scatter of the next).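

In this assay, the change now lies on the aromatic ring itself: on the carbon para to a large group, nitro in place of hydroxy gives a 2.3-fold higher number from compound 1 to compound 4 (0.37 log units; beyond the scatter). The ring therefore stays in place while the number still moves, and compound 4 reads level with the small alkyl compounds, with a 1.3-fold lower number from compound 2 to compound 4 (0.12 log units; within the scatter) and a 1.3-fold lower number from compound 3 to compound 4 (0.12 log units; within the scatter). Nothing available bears on the cause of these steps.

As far as these compounds go, whether an amine, a methoxy group or a fluorine on that carbon would read with compound 1 or with compound 4 stays open.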